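A few compounds are considered here, and "the series" means these few. Any claim that something is new, unique, unknown or untested is made for them only; others in the source may bear on it.

Working notes on the series. The shared core of compound 1 `O=C(Nc1cccc(-n2cc(-c3ccncc3)c(-c3cc(O)cc(Cl)c3)n2)c1)Nc1ccc(Cl)c(C(F)(F)F)c1` carries a urea whose outer aryl bears chloro and trifluoromethyl; in a functional assay on MDA-MB-468 cells (Homo sapiens) for inhibition, read by sulforhodamine B assay, with a stated time of 48 h (on this read-out higher numbers stand for weaker inhibition and lower numbers for stronger inhibition), compound 1 gives 2080 nM. Compound 2 `O=C(Nc1cccc(-n2cc(-c3ccncc3)c(-c3cc(O)cc(Cl)c3)n2)c1)Nc1ccc(Cl)c(Cl)c1` replaces the trifluoromethyl by a second chloro; in this assay compound 2 gives 1710 nM. Among the compounds with values here, the only measured step, a 1.2-fold lower number from compound 1 to compound 2 (0.09 log units; within the scatter), is within the scatter, so the two numbers sit level with each other and neither compound can be set apart from the other on these data.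

Compound 3 `COc1cc(Cl)cc(-c2nn(-c3cccc(NC(=O)Nc4ccc(Cl)c(C(F)(F)F)c4)c3)cc2-c2ccncc2)c1` differs from compound 1 at a different place: methyl in place of hydrogen on an oxygen on an aromatic ring. Within the data shown here, no measured step touches this oxygen, so nothing measured bears directly on the change; the step from compound 1 to compound 2 concerns the urea aryl only. With no guidance from the numbers, the working expectation for compound 3 is a step of about a 1.2-fold higher number from compound 1 to compound 3 (0.08 log units; within the scatter), no larger than the scatter would allow. On that basis compound 3 is estimated at 2500 nM in this assay, with a range from 900 nM to 7000 nM.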

Compound 3, half-maximal inhibitory concentration: 990 nM
Beside the measured number, compound 3's estimate is 2.5-fold (0.40 log units) above it; low and high end bracket the measured number.
By their numbers in this assay, from the lowest: compounds 3, 2 and 1 (each within the scatter of the next, the first and the last beyond it).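

Hydroxy to methoxy on the 3-chloro-5-hydroxyphenyl group gives the first step in the series that lies beyond the scatter: in this assay it produces a 2.1-fold lower number from compound 1 to compound 3 (0.32 log units; beyond the scatter), a modest change, whereas the urea aryl change gave only a 1.2-fold lower number from compound 1 to compound 2 (0.09 log units; within the scatter), which lies within it. The position on this oxygen therefore responds to substitution in this assay, and the hydrogen on the oxygen is not needed for the inhibition read here, since methyl in its place does not weaken the number. The data offer no measurement that would account for this step.

On these data alone, it remains open whether the step is particular to methyl or continues with a longer chain such as ethoxy, and whether the oxygen itself matters, which an amine or a plain fluoro at the same place would test. As far as these compounds go, it is equally open whether the same hydroxy to methoxy change carries over to the dichloro urea aryl of compound 2, as a single pair cannot show whether the effect is independent of the urea aryl.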